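The source may report more compounds than this note shows. Statements on the series, on what has been measured and on what is new or still open speak of the compounds shown alone.

In a functional assay on SMMC-7721 cells (Homo sapiens) for inhibition, read by MTT assay, with a stated time of 48 h (a lower number here means a stronger inhibitor, a higher number a weaker inhibitor), compound 1 (`O=C(Nc1ccncc1)Nc1cc(-c2cccnc2)cc(C(F)(F)F)c1`) offers no single number to start from: its result stands as "not determined" (no result reported). The nearest measured compound is compound 2 (`O=C(Nc1ccncc1)Nc1cc(-c2cncnc2)cc(C(F)(F)F)c1`), and in this assay compound 2 gives 3730 nM. Going by the values given here, that is the only value available for this family of structures, and no step between two measured compounds exists to show how far a single change can move the result.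

Compound 3 (`O=C(Nc1cc(-c2cccnc2)cc(C(F)(F)F)c1)Nc1nccs1`) keeps the core of compound 1 and has 1,3-thiazol-2-yl in place of pyridin-4-yl on an amide-type nitrogen. The data do not show how this change acts in this assay. With no measured starting point for compound 1, no direction can be favoured, and the expected step is none beyond the scatter. The expected level therefore rests on compound 2 at 3730 nM, with a wide margin on both sides. For compound 3 the estimated value is 4000 nM, with an expected range from 1200 nM to 13000 nM.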

Compound 3, half-maximal inhibitory concentration: 68200 nM
Compound 3: middle estimate off by 17-fold (1.23 log units), on the low side, outside the stated range (above it).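

Going by these compounds alone, compound 1 offers no number to set against compound 3 in this assay, so no step between the two can be read. What the compounds shown leave open is how far 1,3-thiazol-2-yl in place of pyridin-4-yl moves the result on its own, and nothing available explains the value of compound 3.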